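Replacing thiophen-2-yl in compound 3

This account rests on a few compounds, and the source may have more. Where it says the series, first, only, none or still open, it means among the compounds named here.

Of the compounds shown here, three sharing one core have been read in a functional assay on HT-29 cells (Homo sapiens) for antiproliferative activity, read by MTT assay, with a stated time of 24 h; on this read-out lower numbers stand for stronger inhibition and higher numbers for weaker inhibition. Compound 1 (`COc1ccc(C(=O)/C=C/c2cccc([N+](=O)[O-])c2)c2c1C=CC(C)(C)O2`) gives 4260 nM. Compound 2 (`COc1ccc(/C=C/C(=O)c2ccc(OC)c3c2OC(C)(C)C=C3)cn1`) reads > 10000 nM, which is a limit of the assay. Compound 3 (`COc1ccc(C(=O)/C=C/c2cccs2)c2c1C=CC(C)(C)O2`) reads > 10000 nM, again a limit. That places compound 3 at the limit of > 10000 nM in this assay, at which 2 of the 3 values shown sit.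

Compound 4 (`COc1ccc(C(=O)/C=C/c2cc(Cl)ccc2O)c2c1C=CC(C)(C)O2`) carries 5-chloro-2-hydroxyphenyl in place of thiophen-2-yl on a double-bonded chain carbon bound to a double-bonded chain carbon. Going by the values given here, two measured steps bear on this change, an at least 2.3-fold higher number from compound 1 to compound 3 (0.37 log units; beyond the scatter) and an at least 2.3-fold higher number from compound 1 to compound 2 (0.37 log units; beyond the scatter), and both lie beyond the scatter. The third, a step that the two limits leave unreadable from compound 2 to compound 3, gives no size.

Compound 4 resembles compound 1 in having a substituted phenyl group at this place, so a modest move to a lower number is expected, with compound 1 at 4260 nM as the guide. The expected change is an at least 1.6-fold lower number from compound 3 to compound 4 (0.22 log units; that floor lies within the scatter) in this assay, though another limit reading remains possible. Compound 4 is estimated at 6000 nM, with an expected range from 2000 nM to 18000 nM.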

Compound 4, half-maximal inhibitory concentration: 4970 nM
Compound 4: middle estimate off by 1.2-fold (0.08 log units), on the high side; low and high end bracket the measured number.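

With compound 4, a second substituted phenyl group on a double-bonded chain carbon bound to a double-bonded chain carbon gives a measurable number in this assay, whereas compound 2 and compound 3 each remain at a limit of the assay: the limit of > 10000 nM in this assay, at which 2 of the 4 values shown sit. Against those two compounds only floors can be given, an at least 2.0-fold lower number from compound 3 to compound 4 (0.30 log units; that floor lies within the scatter) and an at least 2.0-fold lower number from compound 2 to compound 4 (0.30 log units; that floor lies within the scatter), and the full size of either step cannot be read. Against the other measured compound, the result is a 1.2-fold higher number from compound 1 to compound 4 (0.07 log units; within the scatter), so 5-chloro-2-hydroxyphenyl and 3-nitrophenyl cannot be told apart at this place.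

The compounds shown do not separate the contribution of the chlorine from that of the hydroxyl in 5-chloro-2-hydroxyphenyl. They also leave open how a plain phenyl, or a phenyl carrying an amine or a carboxylic acid, would read here.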